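Anomeric configuration swap on a weakly antiproliferative indirubin glycoside

A few compounds are considered here, and "the series" means these few. Any claim that something is new, unique, unknown or untested is made for them only; others in the source may bear on it.

Compound 1 `O=C1/C(=C2/C(=O)N([C@@H]3O[C@H](CO)[C@@H](O)[C@H](O)[C@H]3O)c3ccccc32)Nc2ccccc21`: 28900 nM
Compound 2 `C[C@@H]1O[C@@H](N2C(=O)/C(=C3\Nc4ccccc4C3=O)c3ccccc32)[C@H](O)[C@H](O)[C@H]1O`: > 25000 nM
Compound 3 `C[C@@H]1O[C@H](N2C(=O)/C(=C3\Nc4ccccc4\C3=N/O)c3ccccc32)[C@H](O)[C@H](O)[C@H]1O`: 15400 nM

All three measured compounds sit at the weak end of a functional assay on KYSE-70 cells (Homo sapiens) for antiproliferative activity, read by crystal violet staining, with a stated time of 96 h; on this read-out lower numbers stand for stronger inhibition and higher numbers for weaker inhibition. Compound 1 gives 28900 nM and compound 3 gives 15400 nM. For compound 2 this assay reports only a limit, > 25000 nM, as the evidence notes: the limit of > 25000 nM in this assay, at which 1 of the 3 values shown sits.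

Compound 4 `C[C@@H]1O[C@H](N2C(=O)/C(=C3\Nc4ccccc4C3=O)c3ccccc32)[C@H](O)[C@H](O)[C@H]1O` is the stereoisomer of compound 2: the two compounds have the same atoms and bonds and differ only in configuration as drawn: 1 of 6 stereo elements differ; a stereocentre at a saturated ring carbon is drawn R in compound 2 and S in compound 4. No measured pair in the set isolates this change, so nothing here tells how much a single configuration difference at that ring carbon moves this read-out; the scatter of the assay is the only size to reason from. The expected step is a number no higher from compound 2 to compound 4 (the limit leaves the size open), no more than the scatter allows. Compound 4 is therefore estimated at 25000 nM, between 10000 nM and 60000 nM.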

Compound 4, half-maximal inhibitory concentration: > 12500 nM
Compound 4: no number, only a limit; the forecaster's own chance of this, stated with the estimate: 50%; the middle value is on the limit's open side.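

For the compounds shown here, compound 4 gives > 12500 nM in this assay, a limit and not a number; compound 2 also has only a limit, so no step between compound 2 and compound 4 can be read. As far as these compounds go, how far the single configuration difference at the saturated ring carbon moves antiproliferative activity stays open.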